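Swapping the sulfonyl aryl group in a quinoline-type series

The source may hold more compounds than are shown below. What is called first, only, known or untested is meant among the compounds shown, and "the series" means these compounds.

Of the compounds shown here, two of a shared core have been measured in an ADME assay on microsomes from liver (Homo sapiens) for metabolic stability, tested at 2.5 uM; on this read-out lower numbers stand for slow clearance and higher numbers for fast clearance. Compound 1, `O=S(=O)(c1ccc(F)c(F)c1)c1cnc2cc(F)ccc2c1-c1cccc(Cl)c1`, gives 0.38 mL/min. Compound 2, `COc1cccc(-c2c(S(=O)(=O)c3cc(Cl)cc(Cl)c3)cnc3cc(F)ccc23)c1`, gives 1.51 mL/min in this assay, the highest of the two numbers, and it stands a clear distance above compound 1, beyond the usual scatter of repeated runs. Compound 1 and compound 2 differ in two places at once, so their two values alone do not tell what either change contributes.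

Compound 3, `COc1cccc(-c2c(S(=O)(=O)c3ccc(F)c(F)c3)cnc3cc(F)ccc23)c1`, is not yet measured. It differs from compound 2 in one place: 3,4-difluorophenyl in place of 3,5-dichlorophenyl on a sulfonyl sulfur. The group that enters is the same one that compound 1 carries on its sulfonyl sulfur. Because compound 1 gives 0.38 mL/min in this assay, a move toward a lower number is expected for compound 3, and the step of a 2.2-fold lower number from compound 2 to compound 3 (0.33 log units; beyond the scatter) is estimated to be downward and somewhat beyond the scatter. Compound 3 is therefore expected to read about 0.7 mL/min in this assay, with a likely range from 0.3 mL/min to 1.5 mL/min.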

Compound 3, intrinsic clearance in a liver preparation (reported as CLH), per the amount of preparation that the assay uses: 1.77 mL/min
Estimate against measurement, compound 3: 2.5-fold (0.40 log units) below, outside the stated range (above it).
By their numbers in this assay, from the lowest: compound 1; then compounds 2 and 3 (each within the scatter of the next).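

In this assay the exchange of 3,5-dichlorophenyl for 3,4-difluorophenyl on a sulfonyl sulfur amounts to a 1.2-fold higher number from compound 2 to compound 3 (0.07 log units; within the scatter) and so leaves the read-out within the scatter, which means that these two aryl groups cannot be told apart on this read-out while methoxy stays in the compound. The other single change, methoxy in place of chloro on an aromatic carbon, amounts to a 4.7-fold higher number from compound 1 to compound 3 (0.67 log units; beyond the scatter) in this assay and so gives a clear step, which the pair of compound 1 and compound 2 could not isolate, since they differ in two places at once. Of the two single changes now shown, only this one moves the number beyond the scatter, and the compounds offer no measurement that explains why.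

Going by these compounds alone, whether the exchange on the sulfonyl sulfur would stay as flat with chloro in place of methoxy remains open, since the one step for that exchange carries methoxy on both sides. Also open, as far as these compounds go, is how the read-out would respond to a hydroxyl or an amine in place of methoxy, or to a pyridine ring on the sulfonyl sulfur.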